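Ether side chain series: pentyl to 3-fluorobenzyl

The source may hold more compounds than are shown below. What is called first, only, known or untested is meant among the compounds shown, and "the series" means these compounds.

Measured so far in this assay:
compound 1 `CC(C)COc1ccccc1C1CC(=O)c2ccccc2O1`: 33.5%
compound 2 `CCCCCOc1ccccc1C1CC(=O)c2ccccc2O1`: 40.1%

In a functional assay on J774.A1 cells (Mus musculus) for inhibition, read by immunoassay, with a stated time of 12 h, tested at 30 uM (on this read-out lower numbers stand for less inhibition and higher numbers for more inhibition at the one concentration tested (going by the name of the read-out)), compound 1 gives 33.5% and compound 2 gives 40.1%. Compound 2 holds the higher of the two numbers, yet the step of a number 6.6 percentage points higher from compound 1 to compound 2 (within the scatter) is within the scatter, so the two are not separated. Compound 3 `O=C1CC(c2ccccc2OCc2cccc(F)c2)Oc2ccccc21` differs from compound 2 by 3-fluorophenyl in place of butyl on a saturated chain carbon bound to an oxygen on an aromatic ring. Going by the values given here, the one measured step is a chain change within the scatter; no measured step covers an aromatic ring entering at this place, so the change rests on no comparable data. Compound 3 is expected near compound 2, estimated at 42% with a range of 18% to 66%, a step of a number 1.9 percentage points higher from compound 2 to compound 3 (within the scatter) that is expected to stay within the scatter.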

Compound 3, a percentage reported as inhibition, at one concentration (the size of the read-out at that concentration, not a potency): 92.7%
Compound 3: middle estimate off by 50.7 percentage points, on the low side; measured number outside the range, above it.
By their numbers in this assay, from the lowest: compounds 1 and 2 (each within the scatter of the next); then compound 3.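

In this assay, this position on a saturated chain carbon bound to an oxygen on an aromatic ring responds strongly to what enters. 3-Fluorophenyl in place of butyl gives a number 52.6 percentage points higher from compound 2 to compound 3 (beyond the scatter), and 3-fluorophenyl in place of isopropyl gives a number 59.2 percentage points higher from compound 1 to compound 3 (beyond the scatter), whereas the chain change alone stayed within the scatter. No supporting data bear on the reason for this rise.

Open, as far as these compounds go, is whether the rise belongs to the aromatic ring or to its fluorine. A plain benzyl or a pyridylmethyl at this place would begin to separate these.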